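Adding an Amino Group to the Nitrophenyl Ester

The source may report more compounds than this note shows. Statements on the series, on what has been measured and on what is new or still open speak of the compounds shown alone.

The compounds share one core. Compound 1 `COc1cc(C2Oc3cc([C@H]4Oc5cc(O)cc(O)c5C(=O)[C@@H]4O)ccc3OC2COC(=O)c2ccc(OC)c(OC)c2)ccc1O` carries a 3,4-dimethoxyphenyl on a carbonyl carbon, and in a functional assay on liver (Rattus norvegicus, strain Sprague-Dawley) for inhibition, with a stated time of 1 h (on this read-out higher numbers stand for weaker inhibition and lower numbers for stronger inhibition), compound 1 gives 16000 nM. Compound 2 `COc1cc(C2Oc3cc([C@H]4Oc5cc(O)cc(O)c5C(=O)[C@@H]4O)ccc3OC2COC(=O)c2ccc([N+](=O)[O-])cc2)ccc1O` carries a 4-nitrophenyl in that place; in this assay compound 2 gives 12600 nM. The step of a 1.3-fold lower number from compound 1 to compound 2 (0.10 log units; within the scatter) shows that swapping the aromatic group barely moved the number. Among the measured compounds shown here, on the numbers so far, compound 2 sits at the low end of the two, but its gap to compound 1 is within the scatter, so the two are not distinguished. Compound 3 `COc1cc(C2Oc3cc([C@H]4Oc5cc(O)cc(O)c5C(=O)[C@@H]4O)ccc3OC2COC(=O)c2cc(N)cc([N+](=O)[O-])c2)ccc1O` takes the next step: 3-amino-5-nitrophenyl in place of 4-nitrophenyl on a carbonyl carbon. For the measured compounds named here, the only measured step bearing on this change, a 1.3-fold lower number from compound 1 to compound 2 (0.10 log units; within the scatter), lay within the scatter, and no measured compound carries an amino group. The expected step is therefore a 1.1-fold lower number from compound 2 to compound 3 (0.02 log units; within the scatter), with no clear movement. Compound 3 is expected to give about 12000 nM in this assay, within a likely range of 5000 nM to 30000 nM.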

Compound 3, half-maximal inhibitory concentration: 200 nM
Beside the measured number, compound 3's estimate is 60-fold (1.78 log units) above it; measured number outside the range, below it.
By their numbers in this assay, from the lowest: compound 3; then compounds 2 and 1 (each within the scatter of the next).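

In this assay, the group on this carbonyl carbon proves able to change the number strongly: the step of a 63-fold lower number from compound 2 to compound 3 (1.80 log units; beyond the scatter) is large, while the earlier swap of aromatic groups stayed within the scatter. The step of an 80-fold lower number from compound 1 to compound 3 (1.90 log units; beyond the scatter) is also large, so 3-amino-5-nitrophenyl stands clearly apart from both earlier groups, which cannot themselves be told apart. No available evidence explains this drop.

The compounds shown leave open whether the amino group, the changed place of the nitro group, or the two together account for the step, as 3-amino-5-nitrophenyl differs from 4-nitrophenyl in both respects. A 3-aminophenyl and a 3-nitrophenyl on the same carbonyl carbon would separate these possibilities, and an acetylamino group in place of the amino group would show whether the free amine is needed.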